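The compounds below may be only part of what the source reports. "The series", "measured", "known", "first", "only" and "open" are said of these compounds alone.

Among the measured compounds shown here, compound 3, `COc1cc(C(=O)/C=C\Nc2ccc(-c3nc4cc(OC)c(OC)c(OC)c4s3)cc2)cc([N+](=O)[O-])c1OC`, gives 9800 nM in a functional assay on MDA-MB-231 cells (Homo sapiens) for antiproliferative activity, read by sulforhodamine B assay, with a stated time of 48 h (on this read-out higher numbers stand for weaker inhibition and lower numbers for stronger inhibition), the lowest of the three numbers known here, though its gaps to the other two fall within the scatter. Compound 1, `COc1ccc(C(=O)/C=C\Nc2ccc(-c3nc4cc(OC)c(OC)c(OC)c4s3)cc2)cc1[N+](=O)[O-]`, gives 17100 nM, and compound 2, `COc1ccc(C(=O)/C=C\Nc2ccc(-c3nc4cc(OC)c(OC)c(OC)c4s3)cc2)cc1F`, gives 16500 nM. The two steps that connect them are small: a 1.0-fold lower number from compound 1 to compound 2 (0.02 log units; within the scatter), and a 1.7-fold lower number from compound 1 to compound 3 (0.24 log units; within the scatter).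

Compound 4, `COc1cc(OC)c2sc(-c3ccc(N/C=C\C(=O)c4cc(OC)c(OC)c([N+](=O)[O-])c4)cc3)nc2c1`, differs from compound 3 by hydrogen in place of methoxy on an aromatic carbon. The change sits on an aromatic carbon of the six-membered carbon ring that is part of the fused system of two rings, not on the ring where the step from compound 1 to compound 3 added a methoxy. That earlier step is the only one here that moves a methoxy at all, and it stayed within the scatter. For the measured compounds named here, no measured step touches the fused ring, so the expectation rests on the general picture of small steps across the set.

The step is therefore expected to be no larger than the scatter, a 1.2-fold higher number from compound 3 to compound 4 (0.09 log units; within the scatter), in no particular direction. Compound 4 is estimated at 12000 nM in this assay, with a range from 4500 nM to 32000 nM.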

Compound 4, half-maximal inhibitory concentration: 3060 nM
Compound 4: the middle estimate sits 3.9-fold (0.59 log units) above what was measured, outside the stated range (below it).
By their numbers in this assay, from the lowest: compound 4; then compounds 3, 2 and 1 (each within the scatter of the next).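

Among the compounds shown here, on this assay, hydrogen in place of methoxy on this aromatic carbon gives a 3.2-fold lower number from compound 3 to compound 4 (0.51 log units; beyond the scatter), the only step in the set that lies beyond the scatter, and it shows that the fused system of two rings is a part of the molecule where a single change can move the number. The other methoxy step, a 1.7-fold lower number from compound 1 to compound 3 (0.24 log units; within the scatter), took place elsewhere in the molecule and stayed within the scatter, so among these compounds a methoxy does not count the same at every place: at the carbon ortho to two methoxy groups, its loss goes with a lower number, a modest step resting on one pair of compounds. Nothing shown here accounts for why this step is larger than the others.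

The compounds shown leave open whether it is the absence of a group at this carbon that matters, or whether a hydroxy group, a chlorine atom or an ethoxy group there would give a similar number. They also leave open whether the same change would give a step of this size alongside the fluoro group of compound 2, or whether removing either of the two remaining methoxy groups would do the same.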